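The source may hold more compounds than are shown below. What is called first, only, known or untested is meant among the compounds shown, and "the series" means these compounds.

Measured so far:
Compound 1, `COc1ccc(S(=O)(=O)c2cnc3cc(Cl)ccc3c2N2CCC(C)CC2)cc1Cl`, gives 93%.
Compound 2, `CC1CCN(c2c(S(=O)(=O)c3ccc(Cl)cc3)cnc3c(F)cccc23)CC1`, gives 85%.

Both numbers come from an assay on isolated protein for displacement of a labelled ligand from metabotropic glutamate receptor 5 (Homo sapiens), with a stated time of 60 min, tested at 1 uM; on this read-out lower numbers stand for less inhibition and higher numbers for more inhibition at the one concentration tested (going by the name of the read-out). Compound 2 stands within the usual scatter of compound 1 in this assay, so the two cannot be told apart on these numbers; both show strong displacement of the labelled ligand at the single concentration tested.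

The next compound, compound 3, `CC1CCN(c2c(S(=O)(=O)c3ccc(C#N)cc3)cnc3c(F)cccc23)CC1`, is not yet measured. It differs from compound 2 in one place: cyano in place of chloro on an aromatic carbon. Among the measured compounds shown here, no step between measured compounds of this kind is known, so there is nothing to lean on beyond the two numbers given. A change of this size at that place is expected to leave the read-out roughly where compound 2 put it, with any step from compound 2 to compound 3 expected to be a number 1 percentage points lower from compound 2 to compound 3 (within the scatter), that is, none beyond the scatter. Compound 3 is therefore estimated at 84%, in a range from 65% to 96%.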

Compound 3, a percentage reported as inhibition, at one concentration (the size of the read-out at that concentration, not a potency): 86%
For compound 3 the middle estimate is 2 percentage points below the measured one; the measured number falls inside the stated range.
By their numbers in this assay, from the lowest: compounds 2, 3 and 1 (each within the scatter of the next).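

In this assay, among the compounds shown here, the change from 4-chlorophenyl to 4-cyanophenyl gives a step of a number 1 percentage points higher from compound 2 to compound 3 (within the scatter), the first direct comparison at this place on the aromatic ring, para to a large group. On this read-out, chloro and cyano cannot be told apart at this position, so the extra heavy atom and the added hydrogen-bond acceptor of cyano bring no visible change at the one concentration tested. No measured evidence is available to explain this result.

On these data alone, whether an amine, a carboxylic acid or a longer chain at the same place would also leave the number unchanged remains open. A single concentration also leaves open whether compound 2 and compound 3 would differ in potency across a range of concentrations.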